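The source may hold more compounds than are shown below. What is called first, only, known or untested is meant among the compounds shown, and "the series" means these compounds.

Measured compounds:
- compound 1, `CC(C)n1c(=O)[nH]c2ccc(OCCOc3ccc(Cl)cc3)cc21`: 18.2%
- compound 2, `CC(C)c1ccc(OCCOc2ccc3[nH]c(=O)n(C(C)C)c3c2)cc1`: 14.1%
- compound 3, `CC(C)n1c(=O)[nH]c2ccc(OCCOc3cccc(F)c3)cc21`: 12.9%

In an assay on cells for inhibition of Amine oxidase [flavin-containing] B (Homo sapiens), read by fluorescence, with stated times of 30 min and 15 min, tested at 1 uM (a lower number here means less inhibition, a higher number more inhibition at the concentration tested (going by the name of the read-out)), compound 1 gives 18.2%, the highest of the three numbers, yet its steps to both other compounds stay within the scatter: a number 4.1 percentage points lower from compound 1 to compound 2 (within the scatter), and a number 5.3 percentage points lower from compound 1 to compound 3 (within the scatter). The three measured compounds thus sit together with no separation that can be read as a real difference.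

Compound 4, `Cn1c(=O)[nH]c2ccc(OCCOc3ccc(Cl)cc3)cc21`, has not yet been measured in this assay. It differs from compound 1 in one place: methyl in place of isopropyl on an aromatic nitrogen. Neither measured step concerns this part of the shared core; both touched the other end of the molecule, the ring attached through the oxygen on a saturated carbon, and both were within the scatter. No measured step therefore bears directly on the change from compound 1 to compound 4, and nothing among the shown numbers suggests a move beyond the scatter in either direction.

Compound 4 is therefore expected to give about 15%, between 4% and 28%, which means an expected step of a number 3.2 percentage points lower from compound 1 to compound 4 (within the scatter), within the scatter.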

Compound 4, a percentage reported as inhibition, at one concentration (the size of the read-out at that concentration, not a potency): 9.94%
For compound 4 the middle estimate is 5.1 percentage points above the measured one; the measured number falls inside the stated range.
By their numbers in this assay, from the lowest: compounds 4, 3, 2 and 1 (each within the scatter of the next).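

In this assay the swap of isopropyl for methyl on the aromatic nitrogen gives a number 8.3 percentage points lower from compound 1 to compound 4 (within the scatter) and so no difference that can be read. Within the data shown here, the earlier steps changed only the ring attached through the oxygen, so this is the first measured sign that the group on this nitrogen can also be changed without a clear effect on the inhibition. No measured evidence shown here offers an explanation for the size of this step.

As far as these compounds go, all four compounds lie within the scatter of the next in line, so it remains open whether any group on this nitrogen can separate itself from the others. A longer chain ending in an amine or a carboxylic acid at this place could test that, as could a cyclohexyl ring.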